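Swapping a fluoro for a methyl on an anilide ring

A few compounds are considered here, and "the series" means these few. Any claim that something is new, unique, unknown or untested is made for them only; others in the source may bear on it.

Measured compounds:
- compound 1, `Cc1c(C(=O)N(CC(=O)O)c2ccc(C(F)(F)F)cc2)cnn1-c1ccc(F)cc1`: 3200 nM
- compound 2, `Cc1c(C(=O)Nc2cccc(F)c2)cnn1-c1ccc(F)cc1`: 3000 nM

Both compounds were tested in a functional assay with Homo sapiens as the target; a lower number here means a stronger inhibitor, a higher number a weaker inhibitor. Compound 1 gives 3200 nM, and compound 2 gives 3000 nM. Compound 2 has the lower of the two numbers, but the gap to compound 1 is within the scatter of repeated measurements, so the two cannot be told apart on these values.

Compound 3, `Cc1cccc(NC(=O)c2cnn(-c3ccc(F)cc3)c2C)c1`, has not yet been measured. It differs from compound 2 in a single place: methyl in place of fluoro on an aromatic carbon. The shared core, the amide and the other ring all stay as they are.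

Going by the values given here, with only two measured compounds and no step between them that could guide the reading, there is nothing in the numbers to point towards a large shift in either direction. The change is small in size, so the expectation is a step from compound 2 to compound 3 of about no change at the digits printed from compound 2 to compound 3 (within the scatter), which means none beyond the scatter. Compound 3 is therefore estimated to give 3000 nM in this assay, with a plausible range from 1000 nM to 9000 nM.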

Compound 3, half-maximal inhibitory concentration: 5700 nM
The estimate for compound 3 lay 1.9-fold (0.28 log units) below the measured number; the measured number falls inside the stated range.
By their numbers in this assay, from the lowest: compounds 2, 1 and 3 (each within the scatter of the next).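

In this assay, going by these compounds alone, replacing the fluoro of the 3-fluorophenyl group with methyl gives a 1.9-fold higher number from compound 2 to compound 3 (0.28 log units; within the scatter), and this is the first comparison here that changes one place only, as compound 1 and compound 2 differ in more than one. The step lies within the scatter, so at this position on the aromatic ring, fluoro and methyl cannot be told apart on these numbers, and this one swap of a single heavy atom for another leaves no readable mark on inhibition. Nothing in the data shown explains the size of the step or tells what either group does at this position.

The compounds shown leave open whether this position would accept larger or very different groups, such as an amine, a carboxylic acid or a longer chain like propyl, with equally little effect on the number. They also leave open whether the same swap of fluoro for methyl would read the same way on another carbon of this ring, since a single pair of compounds cannot establish a general pattern.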